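Replacing the piperazine amine of a benzamide dithiocarbamate

The compounds below may be only part of what the source reports. "The series", "measured", "known", "first", "only" and "open" are said of these compounds alone.

Of the compounds shown here, two with a common core have been measured so far. Compound 1 `Nc1ccccc1NC(=O)c1ccc(CSC(=S)N2CCCc3ccccc32)cc1` gives 26.5% in a functional assay on A-375 cells (Homo sapiens) for antiproliferative activity, read by CCK-8 assay, with a stated time of 72 h, tested at 2 uM (on this read-out higher numbers stand for a stronger effect at the one concentration tested and lower numbers for a weaker effect), and compound 2 `CN1CCN(C(=S)SCc2ccc(C(=O)Nc3ccccc3N)cc2)CC1` gives 36.6%. Thus compound 2 stands highest of the two, the one step known being a number 10.1 percentage points higher from compound 1 to compound 2 (beyond the scatter). Compound 3 `CN(Cc1ccncc1)C(=S)SCc1ccc(C(=O)Nc2ccccc2N)cc1` has not yet been measured; it differs from compound 2 in one place, (methyl((pyridin-4-yl)methyl)amino in place of 4-methylpiperazin-1-yl on a thiocarbonyl carbon).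

Within the data shown here, the only step known exchanges one amine on the thiocarbonyl carbon for another, and it was modest; no measured pair tells how the methyl((pyridin-4-yl)methyl)amino group itself behaves, so that step bears on the new one only as a rough guide to how much this position matters. Compound 3 is therefore expected to sit near compound 2, with an estimated step of a number 4.6 percentage points lower from compound 2 to compound 3 (within the scatter) and wide uncertainty. The estimate for compound 3 in this assay is 32%, from 15% to 50%.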

Compound 3, a percentage reported as inhibition, at one concentration (the size of the read-out at that concentration, not a potency): 31.4%
Estimate against measurement, compound 3: 0.6 percentage points above, within the range that was stated.
By their numbers in this assay, from the lowest: compounds 1, 3 and 2 (each within the scatter of the next, the first and the last beyond it).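

The methyl((pyridin-4-yl)methyl)amino group, whose aromatic ring replaces the non-aromatic rings of the earlier amines, is accommodated on the thiocarbonyl carbon: in this assay the exchange gives a number 5.2 percentage points lower from compound 2 to compound 3 (within the scatter). Measured against the other earlier compound, it gives a number 4.9 percentage points higher from compound 1 to compound 3 (within the scatter). Compound 3 thus lies within the scatter of both earlier compounds, even though those two differ beyond it, so this single result cannot assign the open-chain amine to either side of that gap, and the position shows no sharp dependence on the amine among these three compounds.

On these data alone, how a morpholin-4-yl or a dimethylamino group on the same carbon would read remains open, and only one concentration is reported, so these numbers speak only of a stronger or weaker effect at that concentration. No measurement at hand explains these numbers.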